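This account rests on a few compounds, and the source may have more. Where it says the series, first, only, none or still open, it means among the compounds named here.

Measured compounds:
compound 1, `O=C(/N=C1\NC2(CCCCO2)CCS1)c1ccccc1Cl` — in a functional assay on the whole organism (strain CF-1) with Mus musculus as the target, in the writhing test, with a stated time of 15 min (a lower number here means that less compound is needed, a higher number that more compound is needed for the effect), compound 1 gives > 200 mg/kg, which is a limit of the assay rather than a number.
compound 2, `O=C(/N=C1\NC2(CCCCO2)CCS1)c1cccs1` — in this assay compound 2 gives 48 mg/kg.

Compound 2 holds the only number shown in this assay; the one other value is a limit. The exchange of 2-chlorophenyl for thiophen-2-yl on the carbonyl carbon gave an at least 4.1-fold lower number from compound 1 to compound 2 (0.61 log units; beyond the scatter), with compound 1 sitting at the limit of > 200 mg/kg in this assay, at which 1 of the 2 values shown sits, so what stands on that carbon has already moved the number once. Compound 3, `CC1(C(=O)/N=C2\NC3(CCCCO3)CCS2)CCCCC1`, changes the same place: 1-methylcyclohexyl in place of thiophen-2-yl on a carbonyl carbon. Going by the values given here, no measured step exchanges a five-membered aromatic ring for a six-membered non-aromatic ring of carbon only, so the single measured step is a weak guide and gives no firm direction. A modest rise in the number is nonetheless expected, a 1.7-fold higher number from compound 2 to compound 3 (0.22 log units; within the scatter). Compound 3 is therefore estimated at 80 mg/kg, with a range from 25 mg/kg to 250 mg/kg.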

Compound 3, dose for half-maximal effect: > 200 mg/kg
Compound 3: no number, only a limit (the forecaster's own chance of this, stated with the estimate: 25%); middle value at least 2.5-fold (0.39 log units) away from the limit.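

Exchanging thiophen-2-yl for 1-methylcyclohexyl on the carbonyl carbon gave an at least 4.1-fold higher number from compound 2 to compound 3 (0.61 log units; beyond the scatter) in this assay, so a second, quite different group also gives a clearly higher result than thiophen-2-yl at this position. Of the three groups shown on this carbon, thiophen-2-yl is the only one that gives a number rather than a limit, and the step between compound 1 and compound 3 cannot be read, as both values are limits. Compound 3 therefore joins compound 1 at the limit of the assay: the limit of > 200 mg/kg in this assay, at which 2 of the 3 values shown sit.

Going by these compounds, it remains open whether the number of compound 2 depends on the sulfur-containing five-membered aromatic ring, as a furan-2-yl ring or a plain phenyl ring on the same carbon could show. On these data alone, how a simple chain such as ethyl or an amine at this position would behave also stays unknown.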